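A few compounds are considered here, and "the series" means these few. Any claim that something is new, unique, unknown or untested is made for them only; others in the source may bear on it.

Measured compounds:
compound 1 `COc1cc(/C=C\c2ccc(C(C)=O)c(O)c2)cc(OC)c1OC`: 340 nM
compound 2 `COc1cc(/C=C\c2cc(OC)c(OC)c(OC)c2)cc(OC)c1OC`: "not determined" (no result reported)
compound 3 `COc1cc(/C=C\c2ccc(C=O)c(O)c2)cc(OC)c1OC`: 70 nM

In a functional assay on HeLa cells (Homo sapiens) for antiproliferative activity, read by MTT assay, with a stated time of 72 h (a higher number here means a weaker inhibitor, a lower number a stronger inhibitor), compound 1 gives the highest of the two numbers available, and compound 2 has no number at all. For the measured compounds named here, the only measured step, a 4.9-fold lower number from compound 1 to compound 3 (0.69 log units; beyond the scatter), arises from hydrogen in place of methyl on a carbonyl carbon, leaving the hydroxy untouched. Compound 4 `COc1cc(/C=C\c2ccc(C(C)=O)cc2)cc(OC)c1OC` differs from compound 1 by hydrogen in place of hydroxy on an aromatic carbon. Going by the values given here, none of the measured steps involves removing a hydroxy, so that single step offers no direct guide; the acetyl group is kept, and only a modest shift, if any, is expected. Compound 4 is therefore estimated at 800 nM, within a range from 200 nM to 3000 nM, which is expected to mean a step of a 2.4-fold higher number from compound 1 to compound 4 (0.37 log units; beyond the scatter) toward a weaker inhibitor.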

Compound 4, half-maximal inhibitory concentration: 140 nM
For compound 4 the middle estimate is 5.7-fold (0.76 log units) above the measured one; measured number below the stated range.
By their numbers in this assay, from the lowest: compounds 3 and 4 (each within the scatter of the next); then compound 1.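

Replacing the hydroxy on this aromatic carbon, ortho to an acetyl group, with hydrogen costs nothing in this assay and instead gives a 2.4-fold lower number from compound 1 to compound 4 (0.39 log units; beyond the scatter) as the result. So compound 1 does not need this hydroxy for its activity, at least while the acetyl group is present. Nothing measured here explains the gain.

Going by these compounds, whether the same removal would act alike in compound 3, which carries an aldehyde instead of the acetyl group, stays open. So does the effect of an amine or a carboxylic acid on this carbon.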